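This account rests on a few compounds, and the source may have more. Where it says the series, first, only, none or still open, it means among the compounds named here.

Of the compounds shown here, three sharing one core have been measured in a functional assay on HeLa cells (Homo sapiens) for inhibition, read by MTT assay, with a stated time of 72 h; on this read-out lower numbers stand for stronger inhibition and higher numbers for weaker inhibition. Compound 1 `COc1cc(NC(C)CCCNC(=O)Nc2cccc(F)c2)c2ncccc2c1` gives 18000 nM, and compound 2 `COc1cc(NC(C)CCCNC(=O)NNC(=O)Nc2ccc(C(F)(F)F)cc2)c2ncccc2c1` gives 15000 nM. Compound 3 `COc1cc(NC(C)CCCNC(=O)NNC(=O)Nc2cccc(F)c2)c2ncccc2c1` reads > 250000 nM, which is a limit of the assay and not a number. The data show an at least 13-fold higher number from compound 1 to compound 3 (1.14 log units; beyond the scatter) and also an at least 16-fold higher number from compound 2 to compound 3 (1.22 log units; beyond the scatter), so compound 3 is the weakest of the three.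

Compound 4 `COc1cc(NC(C)CCCNC(=O)Nc2ccc(O)cc2)c2ncccc2c1` has not yet been measured. Its difference from compound 3 is 4-hydroxyphenyl in place of ((3-fluorophenyl)carbamoyl)amino on an amide-type nitrogen.

The closest guide is an at least 13-fold higher number from compound 1 to compound 3 (1.14 log units; beyond the scatter), since the same ((3-fluorophenyl)carbamoyl)amino group came in at that step and now leaves. The match is not exact, as 4-hydroxyphenyl enters here rather than 3-fluorophenyl. The other step, an at least 16-fold higher number from compound 2 to compound 3 (1.22 log units; beyond the scatter), shows that the group at the far end can also matter a great deal. Compound 2 carries the longer linkage and still gives 15000 nM, so that linkage can go with a measured number.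

A large step toward a lower number is therefore expected in this assay, and the estimated step is an at least 12-fold lower number from compound 3 to compound 4 (1.09 log units; beyond the scatter). The estimate for compound 4 is 20000 nM, with an expected range of 6000 nM to 80000 nM.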

Compound 4, half-maximal inhibitory concentration: 70000 nM
For compound 4 the middle estimate is 3.5-fold (0.54 log units) below the measured one; low and high end bracket the measured number.
By their numbers in this assay, from the lowest: compounds 2 and 1 (each within the scatter of the next); then compound 4. At a limit, above all of these: compound 3.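

In this assay the shorter linkage also responds to the ring at its far end: with only 3-fluorophenyl giving way to 4-hydroxyphenyl on the amide-type nitrogen, the data show a 3.9-fold higher number from compound 1 to compound 4 (0.59 log units; beyond the scatter). For the compounds shown here, earlier, a change of ring alone had been seen only on the longer linkage, so this comparison extends that sensitivity to the shorter one. Replacing the whole ((3-fluorophenyl)carbamoyl)amino group, which changes the linkage and the ring together, gives an at least 3.5-fold lower number from compound 3 to compound 4 (0.55 log units; beyond the scatter), and this size is only a lower bound since compound 3 stands at a limit and not at a number: the limit of > 250000 nM in this assay, at which 1 of the 4 values shown sits.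

Compound 1 and compound 4 differ both in the ring substituent and in where it sits, so these two effects cannot be told apart here, and a 4-fluorophenyl or a 3-hydroxyphenyl group would separate them. On these data alone, how an amine or a carboxylic acid on that ring would read in this assay also stays open, as does the reading of 4-hydroxyphenyl on the longer linkage.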